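The compounds below may be only part of what the source reports. "The series", "measured", "known", "first", "only" and "open" are said of these compounds alone.

In an in vitro assay on HEK385-7 cells for displacement of a labelled ligand from prostaglandin D2 receptor 2 (Homo sapiens) (on this read-out higher numbers stand for weaker inhibition and lower numbers for stronger inhibition), three compounds have been measured so far:

Compound 1, `O=C(O)Cc1sc(C(c2ccc(F)cc2)c2ccc(F)cc2)nc1-c1ccnc(N2CCC2)c1`, gives 660 nM.
Compound 2, `O=C(O)Cc1sc(C(c2ccccc2)c2ccccc2)nc1-c1ccc(F)c(F)c1`, gives 4.1 nM.
Compound 3, `COc1ccc(C(c2ccccn2)c2nc(-c3ccc(Cl)cc3)c(CC(=O)O)s2)cc1`, gives 61 nM.

Among these three, compound 1 stands at the highest number, which on this read-out means the weakest inhibition. The nearest of the others, compound 3, sits well below it, and compound 2 sits further below still; both gaps lie beyond the usual scatter of repeated measurements, so compound 1 is the weakest of the three.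

Compound 4, `CN(C)c1cc(-c2nc(C(c3ccc(F)cc3)c3ccc(F)cc3)sc2CC(=O)O)ccn1`, has not yet been measured. Compared with compound 1 it carries one change: dimethylamino in place of azetidin-1-yl on an aromatic carbon. For the measured compounds named here, no pair of measured compounds differs by this same change, so there is no measured step to lean on, and the expectation rests on compound 1 alone. The step from compound 1 to compound 4 is expected to be small, a 1.2-fold lower number from compound 1 to compound 4 (0.08 log units; within the scatter), with no direction that reaches beyond the scatter. For compound 4 the estimated result is therefore 550 nM, with a range from 150 nM to 2000 nM.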

Compound 4, half-maximal inhibitory concentration: 380 nM
For compound 4 the middle estimate is 1.4-fold (0.16 log units) above the measured one; the range from low to high includes it.
By their numbers in this assay, from the lowest: compound 2; then compound 3; then compounds 4 and 1 (each within the scatter of the next).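

Exchanging azetidin-1-yl for dimethylamino on the aromatic carbon next to the ring nitrogen gives a 1.7-fold lower number from compound 1 to compound 4 (0.24 log units; within the scatter) in this assay. Compound 1 and compound 4 therefore cannot be told apart on this read-out, which shows that, with the rest of the molecule held the same, this position accepts an open dimethylamino group as well as the closed four-membered ring. Nothing available here offers an explanation for this match between the two compounds.

The compounds shown leave open whether this tolerance extends to other groups at the same carbon, such as methylamino, which keeps a hydrogen on the nitrogen, or piperidin-1-yl, a six-membered ring. They also leave open how a methoxy group or a plain hydrogen there would read in this assay.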